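A few compounds are considered here, and "the series" means these few. Any claim that something is new, unique, unknown or untested is made for them only; others in the source may bear on it.

Measured so far in a functional assay (aorta) with Rattus norvegicus as the target; on this read-out lower numbers stand for stronger inhibition and higher numbers for weaker inhibition:

Compound 1, `CCOC(=O)c1cnnn1CCOCC1=NC(C)=C(C(=O)OC)C(c2ccccc2Cl)/C1=C(\O)OCC`, gives 100 nM.
Compound 2, `CCO/C(O)=C1\C(COCCn2ccnc2C)=NC(C)=C(C(=O)OC)C1c1ccccc1Cl`, gives 2.51 nM.
Compound 3, `CCO/C(O)=C1\C(COCCn2nncc2C(N)=O)=NC(C)=C(C(=O)OC)C1c1ccccc1Cl`, gives 100 nM.

Compound 3 stands together with compound 1 at the weaker end of these three numbers: no change at the digits printed from compound 1 to compound 3 (within the scatter), so the amide and the ester on the triazole sit level. Within the data shown here, the only strong compound is compound 2, and the step of a 40-fold higher number from compound 2 to compound 3 (1.60 log units; beyond the scatter) shows how far the triazole carboxamide falls behind the small imidazole on the same side chain.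

Compound 4, `CCO/C(O)=C1\C(COCCn2cnc3ccccc32)=NC(C)=C(C(=O)OC)C1c1ccccc1Cl`, has not yet been measured. It differs from compound 3 in one place: 1H-benzimidazol-1-yl in place of 5-carbamoyl-1H-1,2,3-triazol-1-yl on a saturated chain carbon, two bonds along the chain from an oxygen on a saturated carbon. Among the measured compounds shown here, the steps that bear on this are a 40-fold lower number from compound 1 to compound 2 (1.60 log units; beyond the scatter) and a 40-fold higher number from compound 2 to compound 3 (1.60 log units; beyond the scatter), both large, and both showing that an imidazole-type ring on this chain gave a far lower number than a triazole carrying a carbonyl group. The benzimidazole that enters is itself an imidazole fused to a carbon ring, so a large step toward lower numbers is expected in this assay, the estimated step being a 17-fold lower number from compound 3 to compound 4 (1.22 log units; beyond the scatter). For compound 4 the estimate is 6 nM, with a likely range from 1.5 nM to 30 nM.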

Compound 4, half-maximal inhibitory concentration: 20 nM
For compound 4 the middle estimate is 3.3-fold (0.52 log units) below the measured one; the measured number falls inside the stated range.
By their numbers in this assay, from the lowest: compound 2; then compound 4; then compounds 1 and 3 (each within the scatter of the next).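

On this chain, the gain over the triazoles is not confined to the small 2-methyl-1H-imidazol-1-yl group: in this assay the 1H-benzimidazol-1-yl group gives a 5.0-fold lower number from compound 3 to compound 4 (0.70 log units; beyond the scatter) and also a 5.0-fold lower number from compound 1 to compound 4 (0.70 log units; beyond the scatter) when set against the ester. The gain is only partial, however, with an 8.0-fold higher number from compound 2 to compound 4 (0.90 log units; beyond the scatter) against the smaller ring, so an imidazole-type ring at this place does not settle the number by itself. The ring on this chain therefore grades the number over a middle level as well as two extremes, and compound 2 stays alone at the low end.

No measurement here explains these differences. A plain 1H-imidazol-1-yl group, with neither the methyl nor the fused carbon ring, could show which of the two separates compound 2 from compound 4, and an unsubstituted 1H-1,2,3-triazol-1-yl group could show whether the triazole ring or its carbonyl substituent holds compound 1 and compound 3 back.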